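Trimming Methoxy Groups on the Ketone Aryl Ring

This account rests on a few compounds, and the source may have more. Where it says the series, first, only, none or still open, it means among the compounds named here.

Of the compounds shown here, three have been measured in an ADME assay on HEK293 cells (Homo sapiens) for antiproliferative activity, read by MTT assay, with a stated time of 24 h; a lower number here means a stronger inhibitor, a higher number a weaker inhibitor. Compound 1 `COc1ccc(-c2cc(/C=C/C(=O)c3cc(OC)c(OC)c(OC)c3)nc3cc(-c4ccccc4)nn23)cc1OC` gives 35000 nM and stands lowest of the two numbers shown. Compound 2 `COc1cc(-c2cc(/C=C/C(=O)c3ccc(C)cc3)nc3cc(-c4ccccc4)nn23)cc(OC)c1OC` is nearest, giving 50400 nM; the gap between compound 1 and compound 2 lies within the usual scatter. Compound 3 `COc1cc(-c2cc(/C=C/C(=O)c3ccccc3)nc3cc(-c4ccccc4)nn23)cc(OC)c1OC` reaches only a limit of the assay, >= 100000 nM, at the limit of >= 100000 nM in this assay, at which 1 of the 3 values shown sits. Within the data shown here, the one measured step, an at least 1.9-fold higher number from compound 2 to compound 3 (0.29 log units; that floor lies within the scatter), is a removal of a methyl group from the aryl ring attached to the carbonyl; its floor lies within the scatter, so it shows at most a modest weakening.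

Compound 4 `COc1ccc(C(=O)/C=C/c2cc(-c3ccc(OC)c(OC)c3)n3nc(-c4ccccc4)cc3n2)cc1` differs from compound 1 by 4-methoxyphenyl in place of 3,4,5-trimethoxyphenyl on a carbonyl carbon. Among the measured compounds shown here, this is again a removal of substituents from the ring on the carbonyl carbon, two methoxy groups fewer, but no measured step removes a methoxy here, so the expectation rests only loosely on the change from compound 2 to compound 3, which weakened inhibition by at most a small margin. A modest weakening, a 1.7-fold higher number from compound 1 to compound 4 (0.23 log units; within the scatter), is therefore expected. Compound 4 is estimated at 60000 nM, within a range from 30000 nM to 150000 nM.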

Compound 4, half-maximal inhibitory concentration: 40000 nM
The estimate for compound 4 lay 1.5-fold (0.18 log units) above the measured number; measured number inside the range.
By their numbers in this assay, from the lowest: compounds 1, 4 and 2 (each within the scatter of the next). At a limit, above all of these: compound 3.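

Among these compounds, replacing 3,4,5-trimethoxyphenyl with 4-methoxyphenyl on the carbonyl carbon gives the first measured step that removes methoxy groups from this ring, and in this assay it is small (a 1.1-fold higher number from compound 1 to compound 4 (0.06 log units; within the scatter)). The numbers of the two compounds cannot be told apart, so on the core of compound 1, this ring keeps its reading with a single methoxy group as well as with the full set of three. No measurement at hand accounts for this.

From the compounds shown here alone, whether the last methoxy group matters on this core stays open, since only the core of compound 3 carries a bare ring there, and >= 100000 nM for compound 3 is a limit of the assay, not a number. How an amine or a carboxylic acid on this ring would read is also unknown.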